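Three Acylhydrazones at the Limit and a Trimethoxyphenyl Analogue

A few compounds are considered here, and "the series" means these few. Any claim that something is new, unique, unknown or untested is made for them only; others in the source may bear on it.

The measured compounds:
compound 1, `CNc1nc(C)c(C(=O)N/N=C/c2cccc(C(F)(F)F)c2)s1`, in a functional assay on HepG2 cells (Homo sapiens) for inhibition, read by MTT assay, with a stated time of 72 h (on this read-out lower numbers stand for stronger inhibition and higher numbers for weaker inhibition), compound 1 gives > 100 ug/mL, a limit of the assay.
compound 2, `Cc1nc(N(C)C(=O)NC(=O)c2c(F)cccc2F)sc1C(=O)N/N=C/c1ccc(Cl)cc1`, in this assay compound 2 gives > 100 ug/mL, a limit of the assay.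
compound 3, `CN(C(=O)NC(=O)c1ccc(Cl)cc1Cl)c1nc(C(F)(F)F)c(C(=O)N/N=C/c2cc(C(F)(F)F)cc(C(F)(F)F)c2)s1`, in this assay compound 3 gives > 100 ug/mL, a limit of the assay.

Compound 2 stands where every measured compound stands: at the limit of > 100 ug/mL in this assay, at which 3 of the 3 values shown sit. Within the data shown here, no numbers below that limit have been obtained, so no step between measured compounds can be read.

Compound 4, `COc1cc(/C=N/NC(=O)c2sc(N(C)C(=O)NC(=O)c3c(F)cccc3F)nc2C)cc(OC)c1OC`, has not yet been measured in this assay. It differs from compound 2 in one place: 3,4,5-trimethoxyphenyl in place of 4-chlorophenyl on a carbon with a double bond to nitrogen. The change is a swap of one aromatic ring for another, and the shared core is kept.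

Among the measured compounds shown here, with the three measured values all at the limit, there is no measured step on which to build. The expected step of a number no higher from compound 2 to compound 4 (the limit leaves the size open) is none beyond the usual scatter. Compound 4 is therefore estimated at 100 ug/mL, with a range from 40 ug/mL to 300 ug/mL, and most likely the assay will again report only a limit.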

Compound 4, half-maximal inhibitory concentration: > 100 ug/mL
Compound 4 was reported as a limit (the forecaster's own chance of this, stated with the estimate: 70%); the middle value lies on the limit itself.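

The swap of 4-chlorophenyl for 3,4,5-trimethoxyphenyl gives no readable step between compound 2 and compound 4 in this assay, as both stand at the same limit: the limit of > 100 ug/mL in this assay, at which 4 of the 4 values shown sit.

The compounds shown leave open how large that step is and what change would bring a value under the limit.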